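The source may report more compounds than this note shows. Statements on the series, on what has been measured and on what is new or still open speak of the compounds shown alone.

Measured compounds:
Compound 1 `CC(=O)C(CSC(=S)N(C)C)CSC(=S)N(C)C` gives 890 nM in a functional assay on NCI-H460 cells (Homo sapiens) for inhibition, read by MTT assay, with a stated time of 72 h; on this read-out higher numbers stand for weaker inhibition and lower numbers for stronger inhibition.
Compound 2 `CN(C)C(=S)SCC(CSC(=S)N(C)C)C(=O)c1ccccc1F` gives 920 nM in this assay.

Among these two numbers compound 2 holds the higher one, though its only neighbour, compound 1, lies within the scatter of it, so the two values cannot be told apart. Among the compounds with values here, the one measured step, a 1.0-fold higher number from compound 1 to compound 2 (0.01 log units; within the scatter), changed the group on the carbonyl carbon and left the number essentially where it was. Compound 3 `CN(C)C(=S)SCC(CSC(=S)N(C)C)C(=O)c1ccc[nH]1` changes the same position once more: 1H-pyrrol-2-yl in place of 2-fluorophenyl on a carbonyl carbon. Within the data shown here, because the step from compound 1 to compound 2 at this carbon was a 1.0-fold higher number from compound 1 to compound 2 (0.01 log units; within the scatter), the only evidence bearing on this place points to little sensitivity of this assay to what sits on the carbonyl carbon. Compound 3 is therefore expected to give a number close to compound 2, with an estimated step of a 1.0-fold lower number from compound 2 to compound 3 (0.01 log units; within the scatter), not beyond the scatter. The estimate for compound 3 is 900 nM, with a range from 400 nM to 2000 nM.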

Compound 3, half-maximal inhibitory concentration: 97300 nM
The estimate for compound 3 lay 110-fold (2.03 log units) below the measured number; the measured number lies above the stated range.
By their numbers in this assay, from the lowest: compounds 1 and 2 (each within the scatter of the next); then compound 3.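

In this assay, the carbonyl carbon proves far from indifferent to what it carries: 1H-pyrrol-2-yl gives a 110-fold higher number from compound 2 to compound 3 (2.02 log units; beyond the scatter) and also a 110-fold higher number from compound 1 to compound 3 (2.04 log units; beyond the scatter), although methyl and 2-fluorophenyl had given values within the scatter of each other. Set against 2-fluorophenyl, the entering group brings a five-membered aromatic ring with 1 hetero atom and 1 hydrogen-bond donor, and this single step changes all of these together, so it cannot show which one matters. Nothing available accounts for the size of this step.

The compounds shown leave open whether the weaker inhibition goes with the hydrogen-bond donor or with the five-membered ring itself. A 1-methylpyrrol-2-yl, furan-2-yl or thiophen-2-yl group on the same carbonyl carbon would separate the two.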